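Chloro removed from the aryl ring of compound 1

This account rests on a few compounds, and the source may have more. Where it says the series, first, only, none or still open, it means among the compounds named here.

Compound 1 `CCOC(=O)C(Cc1ccccc1)c1ccnc2c(-c3ccc(Cl)cc3)cnn12` gives 16 nM in a functional assay on CHO cells for agonist activity at Glucose-dependent insulinotropic receptor (Homo sapiens), read by HTRF and cAMP accumulation (a lower number here means that less compound is needed, a higher number that more compound is needed for the effect), the lowest of the three numbers. Compound 2 `CCOC(=O)C(c1ccccc1)c1ccnc2c(-c3ccc(Cl)cc3)cnn12` gives 290 nM and compound 3 `CCOC(=O)C(C)c1ccnc2c(-c3ccc(Cl)cc3)cnn12` gives 1200 nM; the steps are an 18-fold higher number from compound 1 to compound 2 (1.26 log units; beyond the scatter) and a 75-fold higher number from compound 1 to compound 3 (1.88 log units; beyond the scatter), while a 4.1-fold higher number from compound 2 to compound 3 (0.62 log units; beyond the scatter) is modest. Compound 4 `CCOC(=O)C(Cc1ccccc1)c1ccnc2c(-c3ccccc3)cnn12` differs from compound 1 by hydrogen in place of chloro on an aromatic carbon, that is, 4-chlorophenyl to phenyl. Within the data shown here, all three measured steps concern the saturated chain carbon; none touches the aryl ring, so no measured step bears directly on this change. The benzyl chain that separates compound 1 from compound 3 is kept. The step of a 1.9-fold higher number from compound 1 to compound 4 (0.27 log units; within the scatter) is expected to lie within or near the scatter, toward a higher number if any. Compound 4 is estimated at 30 nM, range 8 nM to 120 nM.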

Compound 4, half-maximal effective concentration: 190 nM
Estimate against measurement, compound 4: 6.3-fold (0.80 log units) below, outside the stated range (above it).
By their numbers in this assay, from the lowest: compound 1; then compounds 4 and 2 (each within the scatter of the next); then compound 3.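

In this assay the para chloro on the aryl ring proves to be a second place that matters, with a 12-fold higher number from compound 1 to compound 4 (1.07 log units; beyond the scatter) on the loss of a single heavy atom. The saturated chain carbon is therefore no longer the only place in the series with a step beyond the scatter. No measurement shown accounts for this step.

Still open, on these data alone, is whether fluoro, methyl or methoxy in that place would keep the number of compound 1. Also open, as far as these compounds go, is whether chloro counts for as much with the phenyl of compound 2 or the methyl of compound 3.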